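Series notes: a ring-free replacement for the substituted pyridine

A few compounds are considered here, and "the series" means these few. Any claim that something is new, unique, unknown or untested is made for them only; others in the source may bear on it.

In a functional assay on a cell-free system (plasma, Homo sapiens) for inhibition, with Plasma (Rattus norvegicus) as the target (on this read-out higher numbers stand for weaker inhibition and lower numbers for stronger inhibition), compound 1 `Cc1c(OCc2cccnc2)ccc2c(N3CCNCC3)cc(=O)oc12` gives 980 nM, compound 2 `CCCCOc1ccc2c(N3CCNCC3)cc(=O)oc2c1C` gives 2790 nM and compound 3 `COc1c(C)cnc(COc2ccc3c(N4CCNCC4)cc(=O)oc3c2C)c1C` gives 3300 nM. Compound 3 therefore sits level with compound 2, as a 1.2-fold higher number from compound 2 to compound 3 (0.07 log units; within the scatter) shows, and apart from compound 1, as a 3.4-fold higher number from compound 1 to compound 3 (0.53 log units; beyond the scatter) shows.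

Compound 4 `COCOc1ccc2c(N3CCNCC3)cc(=O)oc2c1C` carries methoxy in place of 4-methoxy-3,5-dimethylpyridin-2-yl on a saturated chain carbon bound to an oxygen on an aromatic ring. For the measured compounds named here, the nearest precedent is the exchange between propyl and the same substituted pyridine, a 1.2-fold higher number from compound 2 to compound 3 (0.07 log units; within the scatter), since compound 2 also has no ring at this place. The exchange against pyridin-3-yl, a 2.8-fold higher number from compound 1 to compound 2 (0.45 log units; beyond the scatter), is larger, but it concerns only compound 1, which stands alone among the three. Going by the values given here, no measured compound carries methoxy at this place, so the expectation remains loose.

In this assay the expected change, a 1.2-fold lower number from compound 3 to compound 4 (0.07 log units; within the scatter), is none beyond the scatter. Compound 4 is estimated at 2800 nM, with an expected range of 1000 nM to 7000 nM.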

Compound 4, half-maximal inhibitory concentration: 2300 nM
Compound 4: the middle estimate sits 1.2-fold (0.09 log units) above what was measured; low and high end bracket the measured number.
By their numbers in this assay, from the lowest: compound 1; then compounds 4, 2 and 3 (each within the scatter of the next).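

In this assay, the place on a saturated chain carbon bound to an oxygen on an aromatic ring tolerates the loss of 4-methoxy-3,5-dimethylpyridin-2-yl, with its ring and 10 heavy atoms, in favour of methoxy with 2 heavy atoms and no ring (a 1.4-fold lower number from compound 3 to compound 4 (0.16 log units; within the scatter)). Methoxy also stands level with propyl (a 1.2-fold lower number from compound 2 to compound 4 (0.08 log units; within the scatter)), while the remaining step (a 2.3-fold higher number from compound 1 to compound 4 (0.37 log units; beyond the scatter)) leaves pyridin-3-yl as the only group apart from the other three. Nothing available explains why pyridin-3-yl stands apart.

Open, going by these compounds, is whether an amine, a carboxylic acid or a longer chain at this place would stay level with these groups. Also open, on these data alone, is whether unsubstituted pyridin-2-yl or pyridin-4-yl would match pyridin-3-yl.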